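This account rests on a few compounds, and the source may have more. Where it says the series, first, only, none or still open, it means among the compounds named here.

Measured in a functional assay on A20 cells (Mus musculus) for inhibition, with stated times of 1 h, 16 h and 24 h; on this read-out lower numbers stand for stronger inhibition and higher numbers for weaker inhibition:
- Compound 1 `N#CCNC(=O)[C@@H]1CC(F)(F)C[C@H]1C(=O)N1CCOCC1`: 925 nM
- Compound 2 `N#CCNC(=O)[C@@H]1C[C@@H](S(=O)(=O)CC2CC2)C[C@H]1C(=O)N1CCOCC1`: 4510 nM

Only these two compounds have been measured so far. Compound 2, at 4510 nM, holds the higher of the two numbers and so shows the weaker inhibition, and its gap to compound 1 lies beyond the scatter.

Compound 3 `N#CCNC(=O)[C@@H]1C[C@@H](S(=O)(=O)c2ccccc2Cl)C[C@H]1C(=O)N1CCOCC1` has not yet been measured in this assay. It differs from compound 2 by having 2-chlorophenyl in place of cyclopropylmethyl on a sulfonyl sulfur.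

Among the compounds with values here, no measured pair shows this kind of change, so the data give no direct guide to the size of the step. Within the data shown here, the only hint is compound 1 at 925 nM, which shows that a compound with this shared core can give a lower number than compound 2. A step towards stronger inhibition, beyond the scatter, is therefore expected, though with wide uncertainty. The expected change is a 5.0-fold lower number from compound 2 to compound 3 (0.70 log units; beyond the scatter). For compound 3 the estimated value is 900 nM, with an expected range from 180 nM to 4000 nM.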

Compound 3, half-maximal inhibitory concentration: 3 nM
Compound 3: middle estimate off by 300-fold (2.48 log units), on the high side, and the stated range ends above it.
By their numbers in this assay, from the lowest: compound 3; then compound 1; then compound 2.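

In this assay, the group on the sulfonyl sulfur, whose other neighbour is a saturated ring carbon, turns out to have a very large bearing on the read-out: swapping cyclopropylmethyl for 2-chlorophenyl gives a 1500-fold lower number from compound 2 to compound 3 (3.18 log units; beyond the scatter), and this is the only difference between the two structures. Compound 2 at 4510 nM gave no sign that a single group at this place could matter so much. The swap brings in a six-membered aromatic ring and a chlorine in place of a three-membered non-aromatic ring, with neither group adding a hydrogen-bond donor, a hydrogen-bond acceptor or a net charge, and no measurement at hand explains why the number falls so far.

The compounds shown leave open whether the step belongs to the aromatic ring or to the chlorine, as plain phenyl and cyclohexyl do not stand among them. They also leave open how other groups on the sulfonyl sulfur, such as a methoxyphenyl or a pyridine ring, would compare with 2-chlorophenyl.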